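Ethoxy in place of methylamino: working notes on compound 4

A few compounds are considered here, and "the series" means these few. Any claim that something is new, unique, unknown or untested is made for them only; others in the source may bear on it.

Measured in a functional assay on MCF7 cells (Homo sapiens), read by colorimetric assay, with a stated time of 96 h; a higher number here means a weaker inhibitor, a lower number a stronger inhibitor:
- compound 1 `OC[C@@H](O)[C@H]1O[C@@H](n2cnc3c(Cl)nc(Cl)nc32)[C@H](O)[C@@H]1O` gives 54200 nM
- compound 2 `Nc1nc(Cl)nc2c1ncn2[C@@H]1O[C@H]([C@H](O)CO)[C@@H](O)[C@H]1O` gives > 100000 nM as a limit
- compound 3 `CNc1nc(Cl)nc2c1ncn2[C@@H]1O[C@H]([C@H](O)CO)[C@@H](O)[C@H]1O` gives > 100000 nM as a limit

Compound 3 therefore has no number, only a limit, and the limit of > 100000 nM in this assay, at which 2 of the 3 values shown sit, applies to it as well as to compound 2. Compound 4 `CCOc1nc(Cl)nc2c1ncn2[C@@H]1O[C@H]([C@H](O)CO)[C@@H](O)[C@H]1O` differs from it by ethoxy in place of methylamino on an aromatic carbon on the same aromatic carbon. Ethoxy itself has not been measured in this series. The nearest evidence is an at least 1.8-fold higher number from compound 1 to compound 2 (0.26 log units; that floor lies within the scatter) and an at least 1.8-fold higher number from compound 1 to compound 3 (0.26 log units; that floor lies within the scatter), two floors that stay within the scatter. The third step, a step that the two limits leave unreadable from compound 2 to compound 3, adds nothing. No step beyond the scatter is therefore expected in this assay, and no direction can be given. The expected change is an at least 1.1-fold lower number from compound 3 to compound 4 (0.04 log units; that floor lies within the scatter) as an estimate. For compound 4 the estimated value is 90000 nM with an expected range from 35000 nM to 250000 nM as its ends.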

Compound 4, half-maximal inhibitory concentration: > 100000 nM
Compound 4 ended at the assay's limit (the forecaster's own chance of this, stated with the estimate: 55%); middle value at least 1.1-fold (0.04 log units) away from the limit.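

In this assay, ethoxy, which has no hydrogen-bond donor, gives no readable gain over amino or methylamino, which each have one: the limit of > 100000 nM in this assay, at which 3 of the 4 values shown sit. Ethoxy in place of chloro gives an at least 1.8-fold higher number from compound 1 to compound 4 (0.26 log units; that floor lies within the scatter), so this replacement, like the amino and methylamino ones, shows no step beyond the scatter. The steps among compound 2, compound 3 and compound 4 cannot be read, since all three values are limits.

Any order among these three groups remains hidden. On these data alone, whether a thioether, a cyclic amine such as morpholine or a longer alkoxy chain at this position would give a number in this assay stays open.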